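Compound 3 and a ring swap on its amide

A few compounds are considered here, and "the series" means these few. Any claim that something is new, unique, unknown or untested is made for them only; others in the source may bear on it.

Of the compounds shown here, three with much of their structure in common have been measured so far in a physicochemical assay for solubility, read by spectrophotometry, measured as kinetic solubility, at pH 8, tested at 500 uM (on this read-out lower numbers stand for lower solubility and higher numbers for higher solubility), on this scale. Compound 1 `CN1CCC(CNS(=O)(=O)c2ccccc2Nc2cc(-c3ccc4ccn(C)c4c3)c3nccnc3c2)C1` gives 35 ug/mL here, compound 2 `CN(Cc1cncnc1)S(=O)(=O)c1ccccc1Nc1cc(-c2ccc3ccn(C)c3c2)c2nccnc2c1` gives 3 ug/mL here, and compound 3 `Cn1cc(NC(=O)c2ccncc2Nc2cc(-c3ccc4ccn(C)c4c3)c3nccnc3c2)cn1` gives 2 ug/mL in the same test. Compound 3 therefore sits level with compound 2, within the usual scatter of repeat measurements, and well apart from compound 1.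

Compound 4 `CN1CCC(NC(=O)c2ccncc2Nc2cc(-c3ccc4ccn(C)c4c3)c3nccnc3c2)CC1=O` differs from compound 3 in one place only: 1-methyl-2-oxopiperidin-4-yl in place of 1-methyl-1H-pyrazol-4-yl on an amide-type nitrogen and so a five-membered aromatic ring gives way to a six-membered non-aromatic ring.

Within the data shown here, only one measured step offers a guide. That step is a 12-fold lower number from compound 1 to compound 2 (1.07 log units; beyond the scatter) and it is large, well beyond the scatter. There, methyl((pyrimidin-5-yl)methyl)amino replaced ((1-methylpyrrolidin-3-yl)methyl)amino on a sulfonyl sulfur. Read backwards, it links the 1-methylpyrrolidin-3-yl group to the higher number. The guide is loose, since it is a single step with different groups at a different attachment, so a smaller move in the same direction seems reasonable. The expected change is a 4.0-fold higher number from compound 3 to compound 4 (0.60 log units; beyond the scatter) as a moderate estimated rise. For compound 4 the estimate is 8 ug/mL with an expected range from 2.5 ug/mL to 30 ug/mL in this test.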

Compound 4, solubility: 48 ug/mL
For compound 4 the middle estimate is 6.0-fold (0.78 log units) below the measured one, outside the stated range (above it).
By their numbers in this assay, from the lowest: compounds 3 and 2 (each within the scatter of the next); then compounds 1 and 4 (each within the scatter of the next).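

In this assay, a single change on the amide-type nitrogen moves the read-out a long way: a 24-fold higher number from compound 3 to compound 4 (1.38 log units; beyond the scatter) as the 1-methyl-2-oxopiperidin-4-yl group takes the place of the 1-methyl-1H-pyrazol-4-yl group. Among these compounds, the only earlier step was on a sulfonyl sulfur, so this is the first measured sign that the group on this amide-type nitrogen matters in this test, and it comes from swapping a five-membered aromatic ring for a six-membered non-aromatic ring that carries a carbonyl. Nothing available here shows which part of that swap accounts for the rise, whether the ring size, the loss of the aromatic ring or the carbonyl.

The compounds shown leave open how a 1-methylpiperidin-4-yl group, the same ring without its carbonyl, would read on this nitrogen, and that comparison would begin to separate the ring from the carbonyl. Also open, going by these compounds, is whether the same swap would give a similar step on a sulfonyl sulfur, where a different set of groups has been compared so far.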